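Methoxy for fluoro on the benzyl ring of a quinoxaline diamine

The source may hold more compounds than are shown below. What is called first, only, known or untested is meant among the compounds shown, and "the series" means these compounds.

Measured compounds:
compound 1, `Nc1cc(N)c2nc(-c3ccccc3)c(NCc3ccc(Cl)c(Cl)c3)nc2c1`, 15800 nM
compound 2, `COc1ccc(CNc2nc3cc(N)cc(N)c3nc2-c2ccccc2)cc1OC`, 26900 nM
compound 3, `Nc1cc(N)c2nc(-c3ccccc3)c(NCc3ccc(F)cc3)nc2c1`, 4270 nM

In a functional assay on UACC-257 cells (Homo sapiens) for inhibition, read by sulforhodamine B assay, with a stated time of 48 h (on this read-out higher numbers stand for weaker inhibition of growth and lower numbers for stronger inhibition of growth), compound 3 gives the lowest of the three numbers; the step of a 3.7-fold lower number from compound 1 to compound 3 (0.57 log units; beyond the scatter) and the step of a 6.3-fold lower number from compound 2 to compound 3 (0.80 log units; beyond the scatter) both lie beyond the scatter. Compound 4, `COc1ccc(CNc2nc3cc(N)cc(N)c3nc2-c2ccccc2)cc1`, differs from compound 3 in one place: methoxy in place of fluoro on an aromatic carbon. Within the data shown here, no measured step matches this change exactly. Among the measured compounds shown here, the steps that bear on it both end at compound 3 and both show the 4-fluorophenyl compound with the lower number than a compound carrying two groups on that ring, one of them the dimethoxy compound 2. A modest rise in this assay is therefore expected for compound 4, a 2.8-fold higher number from compound 3 to compound 4 (0.45 log units; beyond the scatter), giving an estimated 12000 nM, with a range from 5000 nM to 30000 nM.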

Compound 4, concentration for total growth inhibition: 30200 nM
Estimate against measurement, compound 4: 2.5-fold (0.40 log units) below; the measured number lies above the stated range.
By their numbers in this assay, from the lowest: compound 3; then compounds 1, 2 and 4 (each within the scatter of the next).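

In this assay, the aromatic carbon para to a large group proves sensitive to a single exchange, a 7.1-fold higher number from compound 3 to compound 4 (0.85 log units; beyond the scatter), with methoxy in place of fluoro. The second methoxy of compound 2 adds nothing that can be read, a 1.1-fold higher number from compound 2 to compound 4 (0.05 log units; within the scatter), and the dichloro compound also stays within the scatter, a 1.9-fold higher number from compound 1 to compound 4 (0.28 log units; within the scatter), so among these four only the 4-fluorophenyl compound stands apart. Nothing available here accounts for this difference. The compounds shown leave open how chloro alone, hydroxyl or an amine would read at this carbon, and whether a plain phenyl would fall with compound 3 or with compound 4.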